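The source may report more compounds than this note shows. Statements on the series, on what has been measured and on what is new or still open speak of the compounds shown alone.

In a functional assay on A549 cells (Homo sapiens) for antiproliferative activity, read by MTT assay, with a stated time of 48 h (a higher number here means a weaker inhibitor, a lower number a stronger inhibitor), compound 1 `Fc1ccc2[nH]c(-c3cn(-c4ccccc4)nc3-c3ccccc3)nc2c1` gives 1720 nM and compound 2 `Clc1ccc(-c2nn(-c3ccccc3)cc2-c2nc3ccccc3[nH]2)cc1` gives 5960 nM as the higher of the two numbers. This makes compound 2 the weaker inhibitor of the pair, with a gap beyond the usual scatter. The two compounds differ in more than one place, so no single-change step can be read from them.

Compound 3 `Fc1ccc2[nH]c(-c3cn(-c4ccccc4)nc3-c3ccc(Cl)cc3)nc2c1` follows from compound 2 through fluoro in place of hydrogen on an aromatic carbon on the shared core. The change is fluoro in place of hydrogen on an aromatic carbon of a six-membered aromatic ring of carbon only, part of a fused or bridged system of two rings.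

The expectation in this assay is a modest move to a lower number, possibly not beyond the scatter. For the measured compounds named here, the only support is that compound 1, which also carries this fluoro, reads 1720 nM against compound 2 at 5960 nM in a comparison that also contains their other difference. The estimated change is a 2.1-fold lower number from compound 2 to compound 3 (0.33 log units; beyond the scatter) as a working expectation. For compound 3 the estimated value is 2800 nM within an expected range of 1000 nM to 7500 nM for this measurement.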

Compound 3, half-maximal inhibitory concentration: 4610 nM
Compound 3: middle estimate off by 1.6-fold (0.22 log units), on the low side, within the range that was stated.
By their numbers in this assay, from the lowest: compound 1; then compounds 3 and 2 (each within the scatter of the next).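

In this assay, fluoro in place of hydrogen on an aromatic carbon of the fused system of two rings, with the chloro present in both compounds, gives a 1.3-fold lower number from compound 2 to compound 3 (0.11 log units; within the scatter) and so does not separate this pair. With the fluoro held in both compounds, the added chloro gives a 2.7-fold higher number from compound 1 to compound 3 (0.43 log units; beyond the scatter), a modest step, which makes it the only one of these two single changes that lies beyond the scatter. No supporting measurement bears on what lies behind either step.

From the compounds shown here alone, the fluoro step is read here only with the chloro present, and the chloro step only with the fluoro present, so the size of each step without the other group remains open. Also open, going by these compounds, is how a different group on the same aromatic carbon of the fused system, such as methoxy or an amine, would read against the fluoro in compound 3 in this assay.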